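An Amino Group Added to Two Related Benzyl Compounds

The compounds below may be only part of what the source reports. "The series", "measured", "known", "first", "only" and "open" are said of these compounds alone.

Compound 1 `ClCc1ccc(Cn2cnc3c(Cl)ncnc32)cc1` and compound 3 `ClCc1ccccc1Cn1cnc2c(Cl)ncnc21` are made of the same atoms joined differently; the difference between the two cores is not broken down here. In a functional assay on OVCAR-8 cells (Homo sapiens) for cytotoxicity, read by sulforhodamine B assay, with a stated time of 48 h (on this read-out lower numbers stand for higher toxicity in this test and higher numbers for lower toxicity in this test), compound 1 gives 64600 nM. In this assay compound 3 gives 20400 nM, the lowest of the two numbers recorded, and its gap to compound 1 lies beyond the scatter.

Compound 2 `Nc1nc(Cl)c2ncn(Cc3ccc(CCl)cc3)c2n1` differs from compound 1 in one place, (amino in place of hydrogen on an aromatic carbon). In this assay compound 2 reaches only a limit of the assay, > 100000 nM. The step of an at least 1.5-fold higher number from compound 1 to compound 2 (0.18 log units; that floor lies within the scatter) is therefore read against (the limit of > 100000 nM in this assay, at which 1 of the 3 values shown sits), and its floor lies within the scatter, so the true size of this step is not pinned down by compound 1 and compound 2 alone.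

Compound 4 `Nc1nc(Cl)c2ncn(Cc3ccccc3CCl)c2n1`, not yet measured, differs from compound 3 by amino in place of hydrogen on an aromatic carbon. The surroundings of the change are described in the same words for both pairs, so this is the same change, made here for the second time among the compounds shown. Going by the values given here, the earlier step of an at least 1.5-fold higher number from compound 1 to compound 2 (0.18 log units; that floor lies within the scatter) gives the only guide, and it carries the uncertainty of a limit. Compound 4 is expected to give 45000 nM in this assay, with the estimate spanning from 18000 nM to 110000 nM. This expectation amounts to a step of a 2.2-fold higher number from compound 3 to compound 4 (0.34 log units; beyond the scatter), resting on the step of an at least 1.5-fold higher number from compound 1 to compound 2 (0.18 log units; that floor lies within the scatter) seen between compound 1 and compound 2, and on the lower starting number of compound 3, 20400 nM.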

Compound 4, concentration lethal to 50% of the cells: > 100000 nM
Compound 4: a limit, no number (the forecaster's own chance of this, stated with the estimate: 25%); middle value at least 2.2-fold (0.34 log units) away from the limit.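

In this assay, placing an amino group on the aromatic carbon between two ring nitrogen atoms of the second core gives an at least 4.9-fold higher number from compound 3 to compound 4 (0.69 log units; beyond the scatter), so on this core the change is tied to a higher number by more than the scatter, even at its floor. The change can therefore be carried to the second core without any sign of a lower number, yet the comparison with the first core stops short of a size, and the two steps cannot be called equal or different: the same change on two cores in this assay, an at least 1.5-fold higher number (0.18 log units; that floor lies within the scatter) from compound 1 to compound 2 and an at least 4.9-fold higher number (0.69 log units; beyond the scatter) from compound 3 to compound 4; the limit leaves it open whether they differ. The series thus shows a shared lower bound at most, and not a fixed increment that could be added to any core, and the values offer little room for a finer reading: the limit of > 100000 nM in this assay, at which 2 of the 4 values shown sit.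

On these data alone, how large the step truly is on either core remains open, as compound 2 and compound 4 each carry a limit and not a number. Also open, as far as these compounds go, is whether a smaller change at the same carbon, such as a methyl group or a hydroxyl group in place of the amino group, would give values that can be read as numbers in this assay.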